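This account rests on a few compounds, and the source may have more. Where it says the series, first, only, none or still open, it means among the compounds named here.

In a functional assay on SK-OV-3 cells (Homo sapiens) for inhibition, read by CCK-8 assay, with a stated time of 70 h (on this read-out higher numbers stand for weaker inhibition and lower numbers for stronger inhibition), compound 1 `COc1ccc(COc2ccc(OCCOCCNC3CCCC3)cc2)cc1` gives 15700 nM. Compound 3 `c1ccc(COc2ccc(COc3ccc(OCCOCCNC4CCCC4)cc3)cc2)cc1` gives 10000 nM, and these two stand together on the weaker side of compound 2 `O=[N+]([O-])c1ccccc1COc1ccc(OCCOCCNC2CCCCC2)cc1`, which gives 2880 nM. Compound 4 `Nc1cccc(COc2ccc(OCCOCCNC3CCCC3)cc2)c1` has not yet been measured. It departs from compound 1 in a single place: 3-aminophenyl in place of 4-methoxyphenyl on a saturated chain carbon bound to an oxygen on an aromatic ring. In words, this is 3-aminophenyl in place of 4-methoxyphenyl on a saturated chain carbon bound to an oxygen on an aromatic ring.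

Among the measured compounds shown here, only one measured step bears on this part of the molecule: a 1.6-fold lower number from compound 1 to compound 3 (0.20 log units; within the scatter). For the measured compounds named here, that step stayed within the scatter, so the one available change in this region moved the number very little. Compound 1 and compound 2 differ in more than one place, so the value of compound 2 at 2880 nM cannot be credited to a single group. Going by the values given here, no measured compound carries the amino group, which leaves the evidence thin. On this basis, no step beyond the scatter is expected in this assay, with at most a slight drift towards a lower number. The expected change is a 1.6-fold lower number from compound 1 to compound 4 (0.20 log units; within the scatter). For compound 4 the estimated value is 10000 nM, with an expected range from 4000 nM to 25000 nM.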

Compound 4, half-maximal inhibitory concentration: 10800 nM
Beside the measured number, compound 4's estimate is 1.1-fold (0.03 log units) below it, within the range that was stated.
By their numbers in this assay, from the lowest: compound 2; then compounds 3, 4 and 1 (each within the scatter of the next).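

In this assay, 3-aminophenyl in place of 4-methoxyphenyl on a saturated chain carbon bound to an oxygen on an aromatic ring gives a 1.5-fold lower number from compound 1 to compound 4 (0.16 log units; within the scatter), the second step read at this place. The other step, with phenyl in place of hydrogen on the same carbon, gives a 1.6-fold lower number from compound 1 to compound 3 (0.20 log units; within the scatter), so two quite different changes now leave the number within the scatter of compound 1, and the new one brings in a nitrogen and a hydrogen-bond donor that 4-methoxyphenyl does not have. Nothing shown here offers an explanation for this result.

From the compounds shown here alone, compound 2 gives 2880 nM and differs from compound 1 in more than one place, so it remains open whether its 2-nitrobenzyl group or another of its differences goes with that value. Also open, going by these compounds, is whether any group at this place would move the number beyond the scatter, for instance 4-aminophenyl, which would test the other placing of the amine, or a phenyl ring bearing a carboxylic acid.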